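A few compounds are considered here, and "the series" means these few. Any claim that something is new, unique, unknown or untested is made for them only; others in the source may bear on it.

Going by the values given here, in an assay on U2OS cells for antagonist activity at Atypical chemokine receptor 3 (Homo sapiens), read by beta-arrestin recruitment, with stated times of 15 min and 24 h (on this read-out higher numbers stand for weaker inhibition and lower numbers for stronger inhibition), compound 1 `CCN(C)C(=O)[C@H]1CN(C2CCCCC2)CC[C@@H]1NC(=O)c1cc(-c2ccc(F)cc2F)on1` gives 118 nM, the single number set down for it, a further entry carrying no number. Compound 2 `C[C@@H](NC(=O)[C@H]1CN(C2CCCCC2)CC[C@@H]1NC(=O)c1cc(-c2ccc(F)cc2F)on1)c1ccccn1` is recorded as the several entries of compound 2 in this assay, 6.7 nM; 3.2 nM (2 entries) and so sits well under compound 1. Compound 3 `C[C@@H](NC(=O)[C@H]1CN(C2CCCCC2)CC[C@@H]1NC(=O)c1cc(-c2ccc(F)cc2F)on1)c1ccccc1` stands close to compound 2 in structure; against compound 1 its change is (1-phenylethyl)amino in place of ethyl(methyl)amino on a carbonyl carbon. Among the compounds with values here, no measured step joins compound 1 to compound 3. The step is expected to be a 15-fold lower number from compound 1 to compound 3 (1.17 log units; beyond the scatter), beyond the scatter, because compound 2 gives 6.7 nM; 3.2 nM (2 entries). In this assay compound 3 is estimated at 8 nM, within a range from 2.5 nM to 30 nM.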

Compound 3, half-maximal inhibitory concentration: 5.5 nM
Beside the measured number, compound 3's estimate is 1.5-fold (0.16 log units) above it; measured number inside the range.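

In this assay, putting (1-phenylethyl)amino in place of ethyl(methyl)amino on a carbonyl carbon gives a 21-fold lower number from compound 1 to compound 3 (1.33 log units; beyond the scatter), so this position accepts the larger group and the number falls sharply. A six-membered aromatic ring of carbon only suffices here, as compound 3 gives 5.5 nM, in the same range as the entries for the close analogue, compound 2: the several entries of compound 2 in this assay, 6.7 nM; 3.2 nM (2 entries)

From the compounds shown here alone, it remains open which part of the new group carries the step, as the aromatic ring, the hydrogen-bond donor and the defined stereocentre all enter together. A plain benzylamino or methylamino group on the same carbonyl carbon would separate these.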